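A few compounds are considered here, and "the series" means these few. Any claim that something is new, unique, unknown or untested is made for them only; others in the source may bear on it.

Of the compounds shown here, three built on one shared core have been measured in a toxicity assay on KB cells (Homo sapiens) for cytotoxicity, read by fluorescence, with a stated time of 3 days; on this read-out higher numbers stand for an effect only at larger amounts of compound and lower numbers for an effect already at smaller amounts. Compound 1 `CCCCOC(=O)CNC(=O)[C@H](CSc1ccc([N+](=O)[O-])cc1[N+](=O)[O-])NC(=O)CC[C@H](NC(=O)CC(C)C)C(=O)OCCCC` gives 59.6 uM, compound 2 `CCCCOC(=O)CNC(=O)[C@H](CSc1ccc([N+](=O)[O-])cc1[N+](=O)[O-])NC(=O)CC[C@H](NC(=O)CCC(C)C)C(=O)OCCCC` gives 84 uM, and compound 3 `CCCCOC(=O)CNC(=O)[C@H](CSc1ccc([N+](=O)[O-])cc1[N+](=O)[O-])NC(=O)CC[C@H](NC(=O)C(C)(C)C)C(=O)OCCCC` gives 83.4 uM. Compound 3 holds the second highest of these three numbers, yet both of its steps are within the scatter: a 1.0-fold lower number from compound 2 to compound 3 (0.00 log units; within the scatter) and a 1.4-fold higher number from compound 1 to compound 3 (0.15 log units; within the scatter). Compound 4 `CCCCOC(=O)CNC(=O)[C@H](CSc1ccc([N+](=O)[O-])cc1[N+](=O)[O-])NC(=O)CC[C@H](Nc1nc(N)nc(Cl)n1)C(=O)OCCCC` differs from compound 3 in one place: 4-amino-6-chloro-1,3,5-triazin-2-yl in place of (tert-butyl)carbonyl on an amine nitrogen. The measured steps, including a 1.4-fold higher number from compound 1 to compound 2 (0.15 log units; within the scatter), all swap one small saturated group for another on a carbonyl carbon and all stay within the scatter; none brings in an aromatic ring or a chlorine, so they offer no direct guide here. Compound 4 is therefore expected to land near the measured numbers, with a 1.2-fold lower number from compound 3 to compound 4 (0.08 log units; within the scatter) as the expected step. The estimate for compound 4 in this assay is 70 uM, ranging from 25 uM to 200 uM.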

Compound 4, concentration for half-maximal effect: > 300 uM
Compound 4: no number, only a limit; the forecaster's own chance of this, stated with the estimate: 15%; at least 4.2-fold (0.63 log units) between middle value and limit.
By their numbers in this assay, from the lowest: compounds 1, 3 and 2 (each within the scatter of the next). At a limit, above all of these: compound 4.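

In this assay compound 4 gives no number, only a limit of the assay: the limit of > 300 uM in this assay, at which 1 of the 4 values shown sits.

Putting 4-amino-6-chloro-1,3,5-triazin-2-yl on this amine nitrogen in place of the saturated carbonyl groups gives an at least 3.5-fold higher number from compound 3 to compound 4 (0.55 log units; beyond the scatter), an at least 3.5-fold higher number from compound 2 to compound 4 (0.55 log units; beyond the scatter) and an at least 5.0-fold higher number from compound 1 to compound 4 (0.70 log units; beyond the scatter). The swaps among those carbonyl groups all stayed within the scatter, so this is the first change at this position shown to move the read-out, towards an effect only at larger amounts of compound.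

The compounds shown do not separate the part played by the ring from that of its chlorine or its amino group. A phenyl or a 4,6-diamino-1,3,5-triazin-2-yl group on the same nitrogen would bear on that question.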